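This account rests on a few compounds, and the source may have more. Where it says the series, first, only, none or still open, it means among the compounds named here.

Compound 1 `COc1ccc(/C=C/c2cc(OC)c(OC)c(OC)c2-c2ccccc2)cc1`: 51000 nM
Compound 2 `COc1ccc(/C=C/c2cc(OC)c(OC)c(OC)c2-c2ccc(F)c(C)c2)cc1`: 23000 nM
Compound 3 `COc1ccc(/C=C/c2cc(OC)c(OC)c(OC)c2-c2ccc(OC)c(OC)c2)cc1`: 34000 nM

All three values come from a functional assay on DU-145 cells (Homo sapiens) for cytotoxicity, read by MTT assay, with a stated time of 48 h; a lower number here means a stronger inhibitor, a higher number a weaker inhibitor. Compound 1 has the highest of the three numbers, yet only one of the gaps clears the scatter: there is a 1.5-fold lower number from compound 1 to compound 3 (0.18 log units; within the scatter), and there is a 2.2-fold lower number from compound 1 to compound 2 (0.35 log units; beyond the scatter).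

Compound 4 `COc1cc(/C=C/c2ccc(C)cc2)c(-c2ccccc2)c(OC)c1OC` keeps the core of compound 1 and differs in one place: methyl in place of methoxy on an aromatic carbon. In words, it has methyl in place of methoxy on an aromatic carbon, para to a large group, so that 4-methoxyphenyl becomes 4-methylphenyl.

For the measured compounds named here, no measured step touches this place. All three exchange the phenyl group instead, so they bear on the question only indirectly, by showing how far the numbers have moved among these compounds. Besides the two steps above, there is a 1.5-fold higher number from compound 2 to compound 3 (0.17 log units; within the scatter). The data hold no direct measure of the change from methoxy to methyl. Going by the values given here, with steps this small as the only guide, no step beyond the scatter is expected in this assay, and no direction can be favoured.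

For compound 4 the expected value is 45000 nM, with an estimated range from 20000 nM to 100000 nM. This estimate amounts to an expected 1.1-fold lower number from compound 1 to compound 4 (0.05 log units; within the scatter).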

Compound 4, half-maximal inhibitory concentration: 101000 nM
Estimate against measurement, compound 4: 2.2-fold (0.35 log units) below; the measured number lies above the stated range.
By their numbers in this assay, from the lowest: compounds 2, 3, 1 and 4 (each within the scatter of the next, the first and the last beyond it).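

The change from methoxy to methyl on this aromatic carbon, para to a large group, now has a direct measure in this assay, where there is a 2.0-fold higher number from compound 1 to compound 4 (0.30 log units; within the scatter) and the 4-methoxyphenyl group becomes 4-methylphenyl. The earlier steps shown here all exchanged the phenyl group, whereas this one shows that the methoxy group can give way to methyl, with one heavy atom and one hydrogen-bond acceptor fewer, without the number moving beyond the scatter, so this single pair does not show that the methoxy group matters at this place, nor that it does not. No measurement available here accounts for the size of this step, so the result stands as an observation without an explanation.

The compounds shown leave open what other groups would do at this place, such as a hydroxyl, an amine, a carboxylic acid or a longer chain like butoxy, since methoxy and methyl are the only two seen there. They also leave open whether the exchange of methoxy for methyl would give a similar step on a compound carrying 4-fluoro-3-methylphenyl or 3,4-dimethoxyphenyl in place of the phenyl group.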